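From Compound 3 to Compound 4: One More Methyl

This account rests on a few compounds, and the source may have more. Where it says the series, first, only, none or still open, it means among the compounds named here.

In an ADME assay on microsomes from liver (Homo sapiens) for metabolic stability, with a stated time of 10 min, tested at 0.5 uM (on this read-out lower numbers stand for a less stable compound and higher numbers for a more stable compound), compound 3 (`CCc1noc(C)c1[C@@H]1C[C@@](C)(c2ccc(F)cc2F)N=C(N)S1`) gives 21%. For the measured compounds named here, that number lies within the scatter of the one for compound 1 (`Cc1noc(C)c1[C@@H]1C[C@@](C)(c2ccc(F)cc2F)N=C(N)S1`), which gives 24%. Both sit far from compound 2 (`Cc1noc(C)c1[C@@H]1C[C@@](C)(c2ccccc2)N=C(N)S1`), which gives 86%, a gap well beyond the scatter.

The next compound, compound 4 (`CCc1noc(CC)c1[C@@H]1C[C@@](C)(c2ccc(F)cc2F)N=C(N)S1`), is reached by methyl in place of hydrogen on a saturated chain carbon bound to an aromatic carbon. In words, this is methyl in place of hydrogen on a saturated chain carbon bound to an aromatic carbon, so that a methyl becomes an ethyl.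

Going by the values given here, one measured step bears on this change, since it is described in the same words: a number 3 percentage points lower from compound 1 to compound 3 (within the scatter). Among the compounds with values here, compound 2 offers no such comparison, as no measured step connects it to the other compounds. A single step is thin support, and the data hold no case of this change being made a second time on one compound. Even so, the only precedent stayed within the scatter, so no step beyond the scatter is expected here. The expected change is a number 3 percentage points lower from compound 3 to compound 4 (within the scatter), an estimate with a slight downward lean that stays within the scatter. The estimate for compound 4 is 18%, with an expected range from 8% to 30%.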

Compound 4, percent of the compound remaining: 35%
For compound 4 the middle estimate is 17 percentage points below the measured one, outside the stated range (above it).
By their numbers in this assay, from the lowest: compounds 3 and 1 (each within the scatter of the next); then compound 4; then compound 2.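

In this assay, methyl in place of hydrogen on a saturated chain carbon bound to an aromatic carbon gives a number 14 percentage points higher from compound 3 to compound 4 (beyond the scatter), whereas the same change at a different place on the shared core gave a number 3 percentage points lower from compound 1 to compound 3 (within the scatter). The two steps therefore show that, in this series, a methyl-to-ethyl change does not carry one fixed outcome: its size depends on where it is made, and only at this place does the step lie beyond the scatter. Nothing shown here explains the rise at this place.

The compounds shown leave open whether a longer chain such as propyl, a branched group such as isopropyl, or a cyclopropyl ring at this place would raise the number further, hold it, or lower it again. For the compounds shown here, they also leave open whether methyl-to-ethyl at this place would give a similar step on the core of compound 2, which starts from a much higher number, 86%, and is joined to the other compounds by no single-place step.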